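Solubility of a methylsulfonyl analogue from a hydroxy parent

This account rests on a few compounds, and the source may have more. Where it says the series, first, only, none or still open, it means among the compounds named here.

The comparison starts from compound 1, `CCc1ccc(-c2nc3c(c(C)nn3-c3ccccc3)c(-c3ccccc3O)c2C#N)cc1`. Going by the values given here, in a physicochemical assay for solubility, read by spectrophotometry, in phosphate buffer, with a stated time of 18 h, at pH 7.4 (on this read-out lower numbers stand for lower solubility and higher numbers for higher solubility), compound 1 gives 3100 nM, the lowest of the three numbers so far. Compound 2, `CCc1ccc(-c2nc3c(c(C)nn3-c3ccccc3)c(-c3ccccc3I)c2C#N)cc1`, gives 8500 nM, and compound 3, `CCc1ccc(-c2nc3c(c(C)nn3-c3ccccc3)c(-c3ccccc3C)c2C#N)cc1`, gives 6000 nM. The step of a 2.7-fold higher number from compound 1 to compound 2 (0.44 log units; beyond the scatter) is modest but beyond the scatter, whereas the step of a 1.9-fold higher number from compound 1 to compound 3 (0.29 log units; within the scatter) stays within it, and the step of a 1.4-fold lower number from compound 2 to compound 3 (0.15 log units; within the scatter) likewise stays within it.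

Compound 4, `CCc1ccc(-c2nc3c(c(C)nn3-c3ccccc3)c(-c3ccccc3S(C)(=O)=O)c2C#N)cc1`, differs from compound 1 in one place: methylsulfonyl in place of hydroxy on an aromatic carbon. The change sits on an aromatic carbon of a six-membered aromatic ring of carbon only, ortho to a large group.

The two steps that bear on it are those that also replace the hydroxy group in compound 1, the step to compound 2 and the step to compound 3. Both moved the number upward, one modestly beyond the scatter and one within it. Among the compounds with values here, no step with a methylsulfonyl group has been measured, so the expectation rests on the direction shared by those two steps. The expected step is a 1.6-fold higher number from compound 1 to compound 4 (0.21 log units; within the scatter), a modest rise. Compound 4 is therefore estimated at 5000 nM, with a range from 2000 nM to 12000 nM.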

Compound 4, solubility: 2200 nM
For compound 4 the middle estimate is 2.3-fold (0.36 log units) above the measured one; the range from low to high includes it.
By their numbers in this assay, from the lowest: compounds 4, 1, 3 and 2 (each within the scatter of the next, the first and the last beyond it).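

At this place on the six-membered aromatic ring of carbon only, the replacement of hydroxy by methylsulfonyl in this assay gives a 1.4-fold lower number from compound 1 to compound 4 (0.15 log units; within the scatter) and leaves compound 4 within the scatter of compound 1, so the upward direction seen with iodo and methyl does not extend to this third replacement. Going by these compounds alone, the new compound also opens a separation that the earlier compounds lacked: a 2.7-fold lower number from compound 3 to compound 4 (0.44 log units; beyond the scatter) and a 3.9-fold lower number from compound 2 to compound 4 (0.59 log units; beyond the scatter) both lie beyond the scatter, although compound 2 and compound 3 lie within the scatter of each other, so the group at this one place can move the number beyond the scatter even when hydroxy is not involved. Nothing measured here accounts for why methylsulfonyl parts from methyl and iodo.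

The compounds shown leave open how an amine, a carboxylic acid or a sulfonamide would stand at the same place, and whether any of them would fall with methylsulfonyl or with iodo and methyl. They also leave open whether the separation between methylsulfonyl and methyl would persist if the ethyl group elsewhere on the shared core gave way to a longer chain.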